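Carbamoyl on the ring amine of compound 1

The compounds below may be only part of what the source reports. "The series", "measured", "known", "first", "only" and "open" are said of these compounds alone.

Compound 1 `c1ccc2c(c1)CN[C@@H](CN(CCCN1CCNCC1)[C@H]1CCCc3cccnc31)C2` gives 100%
Compound 2 `c1cnc2c(c1)CN[C@H](CN(CCCN1CCNCC1)[C@H]1CCCc3cccnc31)C2` gives 100%
Compound 3 `c1cnc2c(c1)CN[C@@H](CN(CCCN1CCNCC1)[C@H]1CCCc3cccnc31)C2` gives 79%

In an ADME assay on microsomes from liver (Homo sapiens) for metabolic stability, read by LC-MS, with a stated time of 10 min, tested at 0.5 uM (on this read-out lower numbers stand for a less stable compound and higher numbers for a more stable compound), compound 1 stands level with compound 2, the two sharing the highest number of the three, and compound 3 lies lower. Compound 4 `NC(=O)N1CCN(CCCN(C[C@H]2Cc3ccccc3CN2)[C@H]2CCCc3cccnc32)CC1` carries the change carbamoyl in place of hydrogen on an amine nitrogen in a ring and reads as piperazin-1-yl to 4-carbamoylpiperazin-1-yl, that is, carbamoyl in place of hydrogen on an amine nitrogen in a ring.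

Among the measured compounds shown here, no measured step touches that nitrogen. The exchange on the saturated chain carbon gave no change at the digits printed from compound 1 to compound 2 (within the scatter) in one case and a number 21 percentage points lower from compound 1 to compound 3 (beyond the scatter) in the other, while a number 21 percentage points lower from compound 2 to compound 3 (beyond the scatter) comes with the fact that compounds 2 and 3 differ only in the configuration as drawn and no other difference. These steps set only a scale for the series, none larger than modest. Starting from compound 1 at 100% a small downward move is expected. The expected step is a number 10 percentage points lower from compound 1 to compound 4 (within the scatter) and it rests on that scale alone. For compound 4 the estimate is 90% with 70% and 100% as the expected lower and upper ends.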

Compound 4, percent of the compound remaining: 79%
Compound 4: middle estimate off by 11 percentage points, on the high side; the measured number falls inside the stated range.
By their numbers in this assay, from the lowest: compounds 3 and 4 (each within the scatter of the next); then compounds 1 and 2 (each within the scatter of the next).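

In this assay, among the compounds shown here, carbamoyl in place of hydrogen on an amine nitrogen in a ring gives a number 21 percentage points lower from compound 1 to compound 4 (beyond the scatter), the first measured step at this position. The hydrogen on this nitrogen of the piperazin-1-yl group is therefore not a silent point of change in this read-out, at least for this one replacement, and the step goes beyond the scatter. Nothing on hand bears on why the number moves with this change.

A single replacement cannot show whether the step belongs to carbamoyl itself or to any group on that nitrogen; an acetyl or a methyl group in the same place would separate the two cases. From the compounds shown here alone, whether carbamoyl gives a similar step on the cores of compound 2 and compound 3 also stays open.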